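Chain extension on compound 2: cytotoxicity notes

A few compounds are considered here, and "the series" means these few. Any claim that something is new, unique, unknown or untested is made for them only; others in the source may bear on it.

Compound 1 `CCCCC#Cc1cc2cn([C@@H]3O[C@H](CO)[C@@H](O)[C@H]3O)c(=O)nc2o1` sits at a limit in a functional assay on HEL cells (Homo sapiens) for cytotoxicity; on this read-out lower numbers stand for higher toxicity in this test and higher numbers for lower toxicity in this test: compound 1 gives > 144000 nM, a limit of the assay and not a number (the limit of > 144000 nM in this assay, at which 1 of the 2 values shown sits). Going by the values given here, compound 2 `CCCCCCCCC#Cc1cc2cn([C@@H]3O[C@H](CO)[C@@H](O)[C@@H]3O)c(=O)nc2o1` in this assay gives 49000 nM, the only number recorded so far. Compound 3 `CCCCCCCCCCC#Cc1cc2cn([C@@H]3O[C@H](CO)[C@@H](O)[C@@H]3O)c(=O)nc2o1` carries ethyl in place of hydrogen on a saturated chain carbon, eight bonds along the chain from a triple-bonded carbon. Among the compounds with values here, no step between measured compounds covers this change. The step from compound 2 to compound 3 is expected to be modest, toward higher toxicity, about a 1.6-fold lower number from compound 2 to compound 3 (0.21 log units; within the scatter), and likely not clearly beyond the scatter. Compound 3 is expected to give about 30000 nM in this assay, within 10000 nM to 100000 nM.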

Compound 3, minimum cytotoxic concentration: 46000 nM
For compound 3 the middle estimate is 1.5-fold (0.19 log units) below the measured one, within the range that was stated.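

Ethyl in place of hydrogen on a saturated chain carbon, eight bonds along the chain from a triple-bonded carbon, gives in this assay a 1.1-fold lower number from compound 2 to compound 3 (0.03 log units; within the scatter). Going by these compounds alone, this is the first comparison between compounds that differ in one place, and at this position the change leaves no separable difference in this read-out. No measured property on hand bears on this step.

On these data alone, whether a longer chain would move the value beyond the scatter stays open. So does the effect of an amine or a carboxylic acid at the chain end.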